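Fluorine Added to Compound 1: An Expected Cytotoxicity

The source may report more compounds than this note shows. Statements on the series, on what has been measured and on what is new or still open speak of the compounds shown alone.

Measured so far:
compound 1 `COc1ccc2[nH]cc(C3(c4c[nH]c5ccc(OC)cc45)C(=O)Nc4ccccc43)c2c1`: 3900 nM
compound 2 `COc1ccc2c(C3(c4c[nH]c5cc(OC)ccc45)C(=O)Nc4ccccc43)c[nH]c2c1`: 13600 nM

Of the compounds shown here, two have so far been read in a functional assay on SK-N-SH cells (Homo sapiens) for cytotoxicity, read by MTT assay, with a stated time of 48 h; a higher number here means a weaker inhibitor, a lower number a stronger inhibitor. Of the two numbers, compound 1 holds the lower one; compound 2 sits higher, and the gap between them lies beyond the usual scatter of this assay. Nothing further can be said of that pair, since no single-point change connects them.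

Compound 3 `COc1ccc2[nH]cc(C3(c4c[nH]c5ccc(OC)cc45)C(=O)Nc4ccc(F)cc43)c2c1` is the next candidate. It differs from compound 1 in one place: fluoro in place of hydrogen on an aromatic carbon. Within the data shown here, no measured pair shows what this particular change does in this assay, so the expectation rests on the small size of the change alone. Compound 3 is therefore expected to stay close to compound 1, with a step of a 1.1-fold lower number from compound 1 to compound 3 (0.05 log units; within the scatter) that is not expected to exceed the scatter in either direction. The estimate for compound 3 is 3500 nM, with a plausible range from 1200 nM to 10000 nM.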

Compound 3, half-maximal inhibitory concentration: 7000 nM
Compound 3: the middle estimate sits 2.0-fold (0.30 log units) below what was measured; the range from low to high includes it.
By their numbers in this assay, from the lowest: compounds 1, 3 and 2 (each within the scatter of the next, the first and the last beyond it).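

In this assay, among these compounds, fluoro in place of hydrogen on an aromatic carbon gives a 1.8-fold higher number from compound 1 to compound 3 (0.25 log units; within the scatter) and so provides the first single-place step in this set, which the unconnected pair of compound 1 and compound 2 could not. This aromatic carbon, on the six-membered aromatic ring of carbon only, therefore accepts fluoro without a change that can be told from the scatter of the assay. No accompanying measurement bears on this step, and the result stands without an explanation.

Fluoro is the only replacement shown at this carbon, so it remains open whether chloro, an amine or a carboxylic acid there would also stay within the scatter of compound 1. Also open, from the compounds shown here alone, is how the same fluoro would read on the core of compound 2.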